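From Chloro to Bromo: Compound 3 to Compound 4

A few compounds are considered here, and "the series" means these few. Any claim that something is new, unique, unknown or untested is made for them only; others in the source may bear on it.

In a functional assay on A-375 cells (Homo sapiens) for antiproliferative activity, read by MTT assay, with a stated time of 72 h (a higher number here means a weaker inhibitor, a lower number a stronger inhibitor), compound 1 `Clc1ccc(C2CC(c3ccc(N4CCCCC4)cc3)=NN2c2nc(-c3ccccc3)cs2)cc1` gives 65800 nM. Compound 2 `O=[N+]([O-])c1ccc(-c2csc(N3N=C(c4ccc(N5CCCCC5)cc4)CC3c3ccc(Cl)cc3)n2)cc1` reaches only a limit of the assay, > 100000 nM. Compound 3 `Clc1ccc(-c2csc(N3N=C(c4ccc(N5CCCCC5)cc4)CC3c3ccc(Cl)cc3)n2)cc1` likewise stands at a limit of the assay, > 100000 nM. Compound 3 is therefore not placed as a number; it shares (the limit of > 100000 nM in this assay, at which 2 of the 3 values shown sit). Compound 4 `Clc1ccc(C2CC(c3ccc(N4CCCCC4)cc3)=NN2c2nc(-c3ccc(Br)cc3)cs2)cc1` differs from compound 3 by bromo in place of chloro on an aromatic carbon. The measured steps that touch this aromatic carbon are an at least 1.5-fold higher number from compound 1 to compound 3 (0.18 log units; that floor lies within the scatter) and an at least 1.5-fold higher number from compound 1 to compound 2 (0.18 log units; that floor lies within the scatter), both bounded by the limit, while a step that the two limits leave unreadable from compound 2 to compound 3 cannot be sized. On this footing no readable step in this assay is expected, a step that the limit leaves unreadable from compound 3 to compound 4. Compound 4 is accordingly expected to remain at or near the limit, around 150000 nM (from 60000 nM to 400000 nM).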

Compound 4, half-maximal inhibitory concentration: > 100000 nM
Compound 4: a limit, no number; the forecaster's own chance of this, stated with the estimate: 70%; the middle value does not contradict the limit.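

Compound 4 adds bromo as a third group on this aromatic carbon, and its value in this assay is again a limit. The change from hydrogen reads an at least 1.5-fold higher number from compound 1 to compound 4 (0.18 log units; that floor lies within the scatter). The steps among the three substituted compounds cannot be read, so all that can be said is that chloro, bromo and nitro share one limit here: the limit of > 100000 nM in this assay, at which 3 of the 4 values shown sit.

The compounds shown leave open whether another group on this aromatic carbon, such as an amine or a carboxylic acid, would give a lower number than compound 1. They also leave open what values lie behind the limits of compound 2, compound 3 and compound 4.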